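Methoxyphenyl Placement in a Small Antiproliferative Series

The source may report more compounds than this note shows. Statements on the series, on what has been measured and on what is new or still open speak of the compounds shown alone.

Measured so far in a functional assay on L1210 cells (Mus musculus) for antiproliferative activity, read by MTT assay, with a stated time of 72 h; on this read-out lower numbers stand for stronger inhibition and higher numbers for weaker inhibition:
compound 1, `COc1cccc(C2OC(c3cc(OC)c(OC)c(OC)c3)=NN2C(C)=O)c1`: 45000 nM
compound 2, `COc1ccccc1C1OC(c2cc(OC)c(OC)c(OC)c2)=NN1C(C)=O`: 48000 nM
compound 3, `COc1ccc(C2=NN(C(C)=O)C(c3cccc(OC)c3)O2)cc1`: 41000 nM

All three numbers lie within the usual scatter of one another, so no ranking among compound 1, compound 2 and compound 3 can be drawn from them. For the measured compounds named here, the one single-point change that has been measured is 2-methoxyphenyl in place of 3-methoxyphenyl on a saturated ring carbon. That change produced a 1.1-fold higher number from compound 1 to compound 2 (0.03 log units; within the scatter), a step that does not rise above the noise of repeated measurement.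

Compound 4, `COc1ccc(C2=NN(C(C)=O)C(c3ccccc3OC)O2)cc1`, has not yet been measured in this assay. It differs from compound 3 by 2-methoxyphenyl in place of 3-methoxyphenyl on a saturated ring carbon. Going by the values given here, this is the same kind of change as the one from compound 1 to compound 2, though not the same in every respect: in compound 3 the saturated ring carbon is two ring bonds from the ring atom that bears a 4-methoxyphenyl group (8 heavy atoms), whereas in compound 1 it is two ring bonds from the ring atom that bears a large group. How the core of compound 3 differs from the core of compound 1 is not broken down here.

The step from compound 3 to compound 4 is expected to be a 1.1-fold higher number from compound 3 to compound 4 (0.04 log units; within the scatter), because the same kind of change earlier gave a 1.1-fold higher number from compound 1 to compound 2 (0.03 log units; within the scatter). Compound 4 is therefore estimated at 45000 nM, with a likely range from 25000 nM to 80000 nM.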

Compound 4, half-maximal inhibitory concentration: 5800 nM
Estimate against measurement, compound 4: 7.8-fold (0.89 log units) above; measured number outside the range, below it.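

In this assay, 2-methoxyphenyl in place of 3-methoxyphenyl on the saturated ring carbon gave a 7.1-fold lower number from compound 3 to compound 4 (0.85 log units; beyond the scatter) on the core of compound 3, a step that clears the usual scatter of repeated measurement. The same change therefore did not carry over unchanged from one core to the other, and the two steps stand clearly apart: the same change on two cores in this assay, a 1.1-fold higher number (0.03 log units; within the scatter) from compound 1 to compound 2 and a 7.1-fold lower number (0.85 log units; beyond the scatter) from compound 3 to compound 4, 7.5-fold (0.88 log units) apart, beyond the scatter of two such steps. For the compounds shown here, this shows that the near-silent step on the core of compound 1 was no guide to the step on the core of compound 3, but with a single pair on each core it does not show which difference between the cores is responsible, nor does it establish a rule for the series.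

The compounds shown leave open whether the lower number of compound 4 would survive if a hydroxyl group or a chlorine atom replaced the methoxy group of its 2-methoxyphenyl. They also leave open whether a longer chain such as butanoyl could stand in place of the acetyl group, and how the step would behave on cores carrying other groups at the ring atom that bears the 4-methoxyphenyl group.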